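Cytotoxicity in HEL Cells: From Methoxy to Nitro

The compounds below may be only part of what the source reports. "The series", "measured", "known", "first", "only" and "open" are said of these compounds alone.

Measured so far:
Compound 1, `Cc1cc(-c2cccc(F)c2)c2ncc(CSCCc3ccccc3)n2c1`, gives 20 ug/mL.
Compound 2, `COc1cccc(-c2cc(C)c3ncc(CSCCc4ccccc4)n3c2)c1`, gives 20 ug/mL.
Compound 3, `Cc1cc(-c2ccsc2)c2ncc(CSCCc3ccccc3)n2c1`, gives 100 ug/mL.

In an ADME assay on HEL cells (Homo sapiens) for cytotoxicity, with a stated time of 3 days (a lower number here means that less compound is tolerated, a higher number that more compound is tolerated), compound 2 stands level with compound 1 at the digits shown, and together they give the lowest of the three numbers; compound 3 lies apart, reached by a 5.0-fold higher number from compound 1 to compound 3 (0.70 log units; beyond the scatter). Compound 4, `Cc1cc(-c2cccc([N+](=O)[O-])c2)cn2c(CSCCc3ccccc3)cnc12`, differs from compound 2 by nitro in place of methoxy on an aromatic carbon. Among the compounds with values here, no measured step alters a group on the six-membered aromatic ring of carbon only; the single step on record exchanges that ring itself for another, so it gives little guidance. Compound 1 and compound 2 carry different groups there and give the same number. Compound 4 is therefore expected to stay close to compound 2, with no change at the digits printed from compound 2 to compound 4 (within the scatter), estimated at 20 ug/mL, between 10 ug/mL and 50 ug/mL.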

Compound 4, minimum cytotoxic concentration: >= 100 ug/mL
Compound 4 gave a limit, no number (the forecaster's own chance of this, stated with the estimate: 10%); at least 5.0-fold (0.69 log units) between middle value and limit.
By their numbers in this assay, from the lowest: compounds 1 and 2 (each within the scatter of the next); then compound 3.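

In this assay, nitro in place of methoxy gives an at least 5.0-fold higher number from compound 2 to compound 4 (0.69 log units; beyond the scatter), so changing a group on this six-membered ring, with the ring itself kept, can move the number beyond the scatter. Earlier, the only such shift came with exchange of the ring itself: a 5.0-fold higher number from compound 1 to compound 3 (0.70 log units; beyond the scatter). For compound 4 the result is a limit, not a number: the limit of >= 100 ug/mL in this assay, at which 1 of the 4 values shown sits.

On these data alone, whether this rise is particular to nitro remains open, and an amine or a carboxylic acid on the same ring could test that. As far as these compounds go, how nitro would behave elsewhere on this ring also remains open.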